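Two charged ring ends on a shared collagen-promoter scaffold

A few compounds are considered here, and "the series" means these few. Any claim that something is new, unique, unknown or untested is made for them only; others in the source may bear on it.

Three compounds were run in an assay on LX2 cells for inhibition of COL1A1 promoter (Homo sapiens), read by a luciferase reporter, with a stated time of 24 h, tested at 50 uM; on this read-out lower numbers stand for a weaker effect and higher numbers for a stronger effect at the one concentration tested. Compound 1 `Cc1cc(OCCCCCCC[n+]2ccccc2)cc(-n2cc(C(=O)Nc3cc(F)cc(F)c3)c(=O)c3ccc(N(C)C)nc32)c1` gives 61%. Compound 3 `CC[N+]1(CCCCCCCOc2cc(C)cc(-n3cc(C(=O)Nc4cc(F)cc(F)c4)c(=O)c4ccc(N(C)C)nc43)c2)CCCCC1`, which carries a group of 8 heavy atoms (7 carbon, 1 nitrogen; one six-membered non-aromatic ring with 1 hetero atom) in place of a group of 6 heavy atoms (5 carbon, 1 nitrogen; one six-membered aromatic ring with 1 hetero atom), on a saturated chain carbon, seven bonds along the chain from an oxygen on an aromatic ring, gives 86.6%, so that the step of a number 25.6 percentage points higher from compound 1 to compound 3 (beyond the scatter). Compound 2 `CN(C)c1ccc2c(=O)c(C(=O)Nc3cc(F)cc(F)c3)cn(-c3ccc(Cl)c(OCCCCCCC[n+]4ccccc4)c3)c2n1` gives 77.9%; its value lies within the usual scatter of the value of compound 3 and higher than the value of compound 1, while the difference between the cores of compound 1 and compound 2 is not broken down here.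

Compound 4 `CC[N+]1(CCCCCCCOc2cc(-n3cc(C(=O)Nc4cc(F)cc(F)c4)c(=O)c4ccc(N(C)C)nc43)ccc2Cl)CCCCC1` is the unmeasured partner of compound 2. It differs from compound 2 by a group of 8 heavy atoms (7 carbon, 1 nitrogen; one six-membered non-aromatic ring with 1 hetero atom) in place of a group of 6 heavy atoms (5 carbon, 1 nitrogen; one six-membered aromatic ring with 1 hetero atom), on a saturated chain carbon, seven bonds along the chain from an oxygen on an aromatic ring, the same change that separates compound 3 from compound 1, at the same place along the chain. Among the compounds with values here, only one measured example of that change exists in this set, so the expectation rests on a single step and on the starting point of compound 2.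

Compound 4 is expected to move by a number 11.1 percentage points higher from compound 2 to compound 4 (beyond the scatter) in this assay, a smaller step than the measured one because compound 2 already stands at 77.9%. Compound 4 is therefore estimated at 89% in this assay. The range for compound 4 is expected to run from 78% to 98%.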

Compound 4, a percentage reported as inhibition, at one concentration (the size of the read-out at that concentration, not a potency): "not active" (no number reported)
The entry for compound 4 holds no number; the estimate stays without a comparison.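

In this assay, within the data shown here, compound 4 is recorded as "not active" with no number, so no step from compound 2 to compound 4 can be read. The compounds shown leave open whether the swap of the pyridinium-type aromatic ring end for the non-aromatic ring end acts alike on the two cores. Nothing shown here offers an explanation for this entry.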